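The compounds below may be only part of what the source reports. "The series", "measured", "known", "first", "only" and "open" are said of these compounds alone.

Measured so far:
- compound 1, `COc1cc(-c2cnn3cc(OC)c(C4CCCC4)nc23)ccn1`: 32%
- compound 2, `Cn1cc(-c2nc3c(-c4ccnc(OC5CC5)c4)cnn3cc2OCCCC(C)(C)O)cn1`: 54%

Of the compounds shown here, two have been measured in an ADME assay on microsomes from liver (Homo sapiens) for metabolic stability, with a stated time of 60 min, tested at 1 uM; a lower number here means that less of the compound is left, a higher number that more of the compound is left. Compound 1, with the structure `COc1cc(-c2cnn3cc(OC)c(C4CCCC4)nc23)ccn1`, gives 32% in this assay. Compound 2, with the structure `Cn1cc(-c2nc3c(-c4ccnc(OC5CC5)c4)cnn3cc2OCCCC(C)(C)O)cn1`, gives 54%. Compound 1 therefore holds the lowest of the two numbers, and compound 2 sits higher by a gap that lies beyond the usual scatter of repeated measurements. The two structures differ in several places at once, so no single change can be tied to that gap.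

Compound 3, with the structure `COc1cc(-c2cnn3cc(OC)c([C@@H]4COC(C)(C)C4)nc23)ccn1`, has not yet been measured. Within the data shown here, it keeps the core of compound 1 and changes only one group: a group of 7 heavy atoms (6 carbon, 1 oxygen; one five-membered non-aromatic ring with 1 hetero atom) in place of a group of 5 heavy atoms (5 carbon; one five-membered non-aromatic ring of carbon only), on an aromatic carbon. The cyclopentyl leaves, and a five-membered ring carrying one oxygen, with a defined stereocentre, enters on the same aromatic carbon.

Because compound 1 gives 32%, the open question is whether this single change moves the number upward. A small to moderate rise is expected, a number 13 percentage points higher from compound 1 to compound 3 (beyond the scatter), though a result within the scatter of compound 1 would not be surprising. Compound 3 is estimated to give 45%, within a range from 25% to 65%.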

Compound 3, percent of the compound remaining: 13%
Beside the measured number, compound 3's estimate is 32 percentage points above it; the whole stated range lies above it.
By their numbers in this assay, from the lowest: compound 3; then compound 1; then compound 2.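

In this assay, replacing the cyclopentyl with a five-membered non-aromatic ring that carries one oxygen and a defined stereocentre gives a number 19 percentage points lower from compound 1 to compound 3 (beyond the scatter), so what sits on this aromatic carbon clearly matters. The earlier pair differed in several places at once and could not show this, whereas here a single group changes and the shift lies beyond the usual scatter, with the entering hydrogen-bond acceptor and larger group going along with less of the compound left, not more. No measurement shown accounts for this fall.

A single pair cannot separate the contributions of the ring oxygen, the extra carbons and the stereocentre, nor show whether the other arrangement at that stereocentre would give a different number. It also leaves open how this position would respond to quite different groups, such as an amine or a longer carbon chain in place of the ring, and whether the same swap would have a similar effect on a compound built like compound 2.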